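Swapping Cyclopropyl for Cyano on the Shared Core

A few compounds are considered here, and "the series" means these few. Any claim that something is new, unique, unknown or untested is made for them only; others in the source may bear on it.

For the measured compounds named here, compound 2 `FC(F)(F)c1ccccc1-c1cc2cn[nH]c2cc1C1CC1` stands lowest of the two numbers so far in an assay on CHO-TREX cells for antagonist activity at transient receptor potential cation channel subfamily A member 1 (Homo sapiens), read by FLIPR and calcium flux, with a stated time of 10 min (on this read-out higher numbers stand for weaker inhibition and lower numbers for stronger inhibition), with compound 2 giving 61 nM. Going by the values given here, its only neighbour is compound 1 `FC(F)(F)c1ccccc1-c1ccc2[nH]ncc2c1`, which in this assay gives 164 nM; the step of a 2.7-fold lower number from compound 1 to compound 2 (0.43 log units; beyond the scatter) came from cyclopropyl in place of hydrogen on an aromatic carbon. Compound 3 `N#Cc1cc2[nH]ncc2cc1-c1ccccc1C(F)(F)F` alters that same position: cyano in place of cyclopropyl on an aromatic carbon. Among the compounds with values here, no measured step tests cyano itself; the one step that bears on the position, a 2.7-fold lower number from compound 1 to compound 2 (0.43 log units; beyond the scatter), shows that the three-carbon ring there gave a modest gain over bare hydrogen, so taking it away may hand part of that gain back, while the cyano group remains an untested unknown. The expected step is a 2.1-fold higher number from compound 2 to compound 3 (0.33 log units; beyond the scatter), a rise in the number toward compound 1, beyond the scatter. The estimate for compound 3 in this assay is 130 nM, within 40 nM to 420 nM.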

Compound 3, half-maximal inhibitory concentration: 129 nM
The estimate for compound 3 lay 1.0-fold (0.00 log units) above the measured number, within the range that was stated.
By their numbers in this assay, from the lowest: compound 2; then compounds 3 and 1 (each within the scatter of the next).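

In this assay, cyano does not keep the gain that cyclopropyl brought to this position on the shared core: the change gives a 2.1-fold higher number from compound 2 to compound 3 (0.33 log units; beyond the scatter). Set against bare hydrogen, cyano gives a 1.3-fold lower number from compound 1 to compound 3 (0.10 log units; within the scatter), so at this place the cyano group cannot be told apart from having no added group, and cyclopropyl remains the only group here shown to lower the number. Nothing measured here explains why the two groups differ.

Still open, going by these compounds, is whether the gain belongs to the three-membered ring itself or would appear with other carbon groups at this place. A methyl or an ethyl group here would show whether a carbon group without the ring keeps the lower number, and an amine would test a group of a different kind.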